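Removing the Fluorine from Compound 1

The source may hold more compounds than are shown below. What is called first, only, known or untested is meant among the compounds shown, and "the series" means these compounds.

Compound 1, `NS(=O)(=O)c1ccc(Nc2ncc(F)c(Nc3nc4ccccc4s3)n2)cc1`: 4520 nM
Compound 2, `Cc1ccc2nc(Nc3ccnc(Nc4ccc(S(C)(=O)=O)cc4)n3)sc2c1`: 2300 nM
Compound 3, `CS(=O)(=O)c1ccc(Nc2ncc(F)c(Nc3nc4ccccc4s3)n2)cc1`: 3170 nM

Of the compounds shown here, three have been measured in a functional assay on HeLa cells (Homo sapiens) for antiproliferative activity, read by MTT assay, with a stated time of 48 h; a higher number here means a weaker inhibitor, a lower number a stronger inhibitor. Compound 1 carries the highest number of the three, but the gap to compound 3, a 1.4-fold lower number from compound 1 to compound 3 (0.15 log units; within the scatter), is small, and compound 2 sits within the usual scatter of compound 1 as well. Compound 4, `NS(=O)(=O)c1ccc(Nc2nccc(Nc3nc4ccccc4s3)n2)cc1`, differs from compound 1 in one place: hydrogen in place of fluoro on an aromatic carbon. Among the measured compounds shown here, no measured step speaks to this change; the only single-point step, from compound 1 to compound 3, alters the sulfonyl group instead. With nothing pointing in either direction, compound 4 is expected to stay close to compound 1, so the step of a 1.1-fold lower number from compound 1 to compound 4 (0.05 log units; within the scatter) is estimated to fall within the scatter. Compound 4 is therefore estimated at 4000 nM, with a likely range from 1500 nM to 11000 nM.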

Compound 4, half-maximal inhibitory concentration: 2060 nM
The estimate for compound 4 lay 1.9-fold (0.29 log units) above the measured number; the measured number falls inside the stated range.
By their numbers in this assay, from the lowest: compounds 4, 2, 3 and 1 (each within the scatter of the next, the first and the last beyond it).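

In this assay, among the compounds shown here, hydrogen in place of fluoro on this aromatic carbon gives a 2.2-fold lower number from compound 1 to compound 4 (0.34 log units; beyond the scatter) and is the first step at this position, as well as the first single change to pass beyond the scatter. Compound 1 therefore does not need its fluoro to keep this activity, and losing it brings a modest gain. Nothing measured here accounts for that gain.

From the compounds shown here alone, whether a chloro, methyl or methoxy group at this carbon would do better stays open. So does whether removing fluoro from compound 3 would give a similar step.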